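Removing the amino group from compound 2

The compounds below may be only part of what the source reports. "The series", "measured", "known", "first", "only" and "open" are said of these compounds alone.

Compound 1 `CCCCC(CCO)n1cnc2cncnc21`: > 50000 nM
Compound 2 `CCCCCCC(CCO)n1cnc2c(N)ncnc21`: > 50000 nM

Both compounds were tested in a functional assay on SW480 cells (Homo sapiens) for antiproliferative activity, read by MTT assay, with a stated time of 48 h; a lower number here means a stronger inhibitor, a higher number a weaker inhibitor. Compound 1 gives > 50000 nM, which is a limit of the assay and not a number. Compound 2 gives > 50000 nM, which is also a limit. Compound 2 therefore has no exact value, and the whole data set so far amounts to the limit of > 50000 nM in this assay, at which 2 of the 2 values shown sit.

The next compound is compound 3 `CCCCCCC(CCO)n1cnc2cncnc21`. It differs from compound 2 in one place: hydrogen in place of amino on an aromatic carbon. In words, hydrogen stands in place of amino on an aromatic carbon. Within the data shown here, no measured pair shows what this exchange does, so the size of the step cannot be read from earlier results.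

In this assay, no shift beyond the usual scatter is expected in either direction, and compound 3 will probably stay weak. This expectation rests on the limit of compound 2 at > 50000 nM. The expected change is a number no higher from compound 2 to compound 3 (the limit leaves the size open). The estimated value for compound 3 is 50000 nM, with an expected range from 20000 nM to 100000 nM.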

Compound 3, half-maximal inhibitory concentration: > 50000 nM
Compound 3 was reported as a limit; the forecaster's own chance of this, stated with the estimate: 70%; the middle value lies on the limit itself.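

No step can be read from compound 2 to compound 3 or from compound 1 to compound 3, since each value is a limit of the assay and not a number: the limit of > 50000 nM in this assay, at which 3 of the 3 values shown sit.

The compounds shown leave open what hydrogen in place of amino, or ethyl in place of hydrogen, does to antiproliferative activity.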